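A few compounds are considered here, and "the series" means these few. Any claim that something is new, unique, unknown or untested is made for them only; others in the source may bear on it.

Measured compounds:
Compound 1 `COc1ccc(Sc2nc3cc(N)cc(N)c3nc2-c2ccccc2)cc1` — in a functional assay on SF-268 cells (Homo sapiens) for inhibition, read by sulforhodamine B assay, with a stated time of 48 h (a higher number here means a weaker inhibitor of growth, a lower number a stronger inhibitor of growth), compound 1 gives < 100000 nM, which is a limit of the assay and not a number.
Compound 2 `Nc1cc(N)c2nc(-c3ccccc3)c(Oc3ccc(F)cc3)nc2c1` — in this assay compound 2 gives 47900 nM.

Compound 2 thus holds the only number shown, the other value being (the limit of < 100000 nM in this assay, at which 1 of the 2 values shown sits). The step that the limit leaves unreadable from compound 1 to compound 2 cannot be read in size. Compound 3 `Nc1cc(N)c2nc(-c3ccccc3)c(Sc3ccc(F)cc3)nc2c1` differs from compound 2 by (4-fluorophenyl)sulfanyl in place of 4-fluorophenoxy on an aromatic carbon. For the measured compounds named here, no measured step bears on this change, so in this assay no step beyond the scatter is expected in either direction. Compound 3 is therefore estimated at 45000 nM, between 12000 nM and 100000 nM. This corresponds to an expected step of a 1.1-fold lower number from compound 2 to compound 3 (0.03 log units; within the scatter).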

Compound 3, concentration for total growth inhibition: 38900 nM
The estimate for compound 3 lay 1.2-fold (0.06 log units) above the measured number; the measured number falls inside the stated range.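

In this assay, for the compounds shown here, (4-fluorophenyl)sulfanyl in place of 4-fluorophenoxy on this aromatic carbon gives a 1.2-fold lower number from compound 2 to compound 3 (0.09 log units; within the scatter), the first readable comparison at this position. With the fluorinated aryl group kept, the sulfur and oxygen links are thus not told apart by this read-out. The steps from compound 1 cannot be read, because compound 1 stands at a limit of the assay, not a number: the limit of < 100000 nM in this assay, at which 1 of the 3 values shown sits.

Going by these compounds, it remains open whether an amine or a methylene link at this position would move the number beyond the scatter. Whether fluoro and methoxy differ also stays unresolved.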